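Methylating a phenol on a compound without measurable inhibition

The source may hold more compounds than are shown below. What is called first, only, known or untested is meant among the compounds shown, and "the series" means these compounds.

Compound 2 `Cc1ccccc1NC(=O)/C=C/c1coc2cc(O)ccc2c1=O` was tested in a functional assay on A549 cells (Homo sapiens) for inhibition, read by MTT assay, with a stated time of 48 h; on this read-out higher numbers stand for weaker inhibition and lower numbers for stronger inhibition. In this assay compound 2 gives > 100000 nM, which is a limit of the assay and not a number. Compound 1 `COc1ccc2c(=O)c(/C=C/C(=O)NCc3ccc(C)cc3)coc2c1` was tested the same way. In this assay compound 1 gives > 100000 nM, again a limit rather than a number. Among the compounds with values here, both results sit at the same limit (the limit of > 100000 nM in this assay, at which 2 of the 2 values shown sit), so neither compound shows inhibition that can be measured here, and no step between them can be sized.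

Compound 3 `COc1ccc2c(=O)c(/C=C/C(=O)Nc3ccccc3C)coc2c1` has not yet been measured. It differs from compound 2 in one place: methyl in place of hydrogen on an oxygen on an aromatic ring. Compound 1 already carries the methoxy group and in this assay gives > 100000 nM, a limit, so the methyl alone has not brought activity into view. Within the data shown here, no measured step exists for this change. The expected step in this assay is therefore none beyond the scatter, namely a step that the limit leaves unreadable from compound 2 to compound 3. Compound 3 is estimated at 150000 nM, in a range from 30000 nM to 1000000 nM, and is expected most likely to be reported again only as a limit.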

Compound 3, half-maximal inhibitory concentration: 23400 nM
The estimate for compound 3 lay 6.4-fold (0.81 log units) above the measured number, and the stated range ends above it.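

In this assay, within the data shown here, placing a methyl on the oxygen on the aromatic ring, which turns hydroxy into methoxy, gives an at least 4.2-fold lower number from compound 2 to compound 3 (0.63 log units; beyond the scatter) and so brings measurable inhibition into view for the first time in this set. The methoxy group is not enough on its own, since compound 1 carries it too, and replacing 4-methylbenzyl with 2-methylphenyl on the amide-type nitrogen gives an at least 4.2-fold lower number from compound 1 to compound 3 (0.63 log units; beyond the scatter), which shows that the group on that nitrogen also counts. Both steps are minimum sizes and their true sizes cannot be read, because compound 1 and compound 2 each stand at a limit of the assay and not at a number: the limit of > 100000 nM in this assay, at which 2 of the 3 values shown sit.

Going by these compounds, it remains open whether a longer chain on that oxygen, such as ethyl, or an amine in place of the methoxy group would lower the number further or lose the inhibition again. Also open, on these data alone, is whether 2-methylphenyl would give measurable inhibition with the hydroxy group in place, or whether it needs the methoxy group to do so.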